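Methylthio benzylamine analogue: dropping the methoxy

The source may hold more compounds than are shown below. What is called first, only, known or untested is meant among the compounds shown, and "the series" means these compounds.

Measured compounds:
- compound 1, `[SeH]c1nc(NCc2ccccc2)c2cccnc2n1`: 9130 nM
- compound 2, `COc1ccc(CNc2nc(SC)nc3ncccc23)cc1`: 69800 nM
- compound 3, `C[Se]c1nc(N)c2cccnc2n1`: 87200 nM

In an ADME assay on 184B5 cells (Homo sapiens) for cytotoxicity, read by MTT assay, with a stated time of 72 h (on this read-out lower numbers stand for stronger inhibition of growth and higher numbers for weaker inhibition of growth), compound 2 gives 69800 nM, the second highest of the three numbers. Its nearest neighbour is compound 3, which in this assay gives 87200 nM, within the scatter of compound 2. Furthest away is compound 1, which in this assay gives 9130 nM, a clearly lower number than compound 2.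

Compound 4, `CSc1nc(NCc2ccccc2)c2cccnc2n1`, differs from compound 2 in one place: hydrogen in place of methoxy on an aromatic carbon. Going by the values given here, no step of this kind is present among the measured compounds, so nothing measured here bears on it directly. The change is small in atom count and leaves the shared core and the methylthio group untouched, so the expected step in this assay is small, at most marginally toward a lower number, and likely within the scatter.

The estimate for compound 4 in this assay is 50000 nM, in the range 15000 nM to 160000 nM, which means an expected step of a 1.4-fold lower number from compound 2 to compound 4 (0.14 log units; within the scatter).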

Compound 4, concentration for total growth inhibition: > 100000 nM
Compound 4 was reported as a limit; the forecaster's own chance of this, stated with the estimate: 10%; at least 2.0-fold (0.30 log units) between middle value and limit.
By their numbers in this assay, from the lowest: compound 1; then compounds 2 and 3 (each within the scatter of the next). At a limit, above all of these: compound 4.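

In this assay compound 4 gives > 100000 nM, which is a limit of the assay and not a number. Hydrogen in place of methoxy on this aromatic carbon, para to a large group, brings no move toward a lower number; the step is an at least 1.4-fold higher number from compound 2 to compound 4 (0.15 log units; that floor lies within the scatter), and that floor alone does not separate hydrogen from methoxy at this place. The clear change lies elsewhere, with the methylthio group in place of selenium on the shared core giving an at least 10-fold higher number from compound 1 to compound 4 (1.03 log units; beyond the scatter).

As far as these compounds go, how far the two steps really reach stays unread because compound 4 sits at the ceiling of the read-out: the limit of > 100000 nM in this assay, at which 1 of the 4 values shown sits. Also open is whether a chlorine atom or a hydroxyl group in place of methoxy, or a longer chain in place of the methylthio group, would shift the number.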